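A Hexyl Chain Replaces Cyclopropylamino

The source may hold more compounds than are shown below. What is called first, only, known or untested is meant among the compounds shown, and "the series" means these compounds.

Compound 1 `CC(C)CSc1nc(N)nc2c1ncn2/C=C1/CC1(CO)CO`: > 20000 nM (a limit)
Compound 2 `Nc1nc(NCc2ccccc2)c2ncn(/C=C3/CC3(CO)CO)c2n1`: 19900 nM
Compound 3 `Nc1nc(NC2CC2)c2ncn(/C=C3/CC3(CO)CO)c2n1`: 71500 nM

These results come from an ADME assay on BCBL1 cells (Homo sapiens) for cytotoxicity, with a stated time of 7 days; a lower number here means that less compound is tolerated, a higher number that more compound is tolerated. The entry for compound 1, > 20000 nM, is a limit of the assay and not a number. Compound 3 has the higher of the two readable values, 71500 nM, against compound 2 at 19900 nM.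

Compound 4 `CCCCCCSc1nc(N)nc2c1ncn2/C=C1/CC1(CO)CO` has not yet been measured. It carries hexylsulfanyl in place of cyclopropylamino on an aromatic carbon.

The nearest measured comparison is a step that the limit leaves unreadable from compound 1 to compound 3, since compound 1 also has a sulfur-linked chain, but it gives no size. Among the measured compounds shown here, the only readable step is a 3.6-fold higher number from compound 2 to compound 3 (0.56 log units; beyond the scatter), which leaves compound 3 at the top of the readable values and suggests a modest change. A modest fall is therefore expected, though with wide uncertainty. The estimated step is a 2.6-fold lower number from compound 3 to compound 4 (0.41 log units; beyond the scatter). For compound 4, the expected value is 28000 nM, with an estimated range of 9000 nM to 85000 nM.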

Compound 4, half-maximal cytotoxic concentration: > 20000 nM
Compound 4: a limit, no number (the forecaster's own chance of this, stated with the estimate: 45%); the middle value does not contradict the limit.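

In this assay compound 4 gives > 20000 nM, which is a limit of the assay and not a number. Among the compounds shown here, the one step that shows a direction is a number no lower from compound 2 to compound 4 (the limit leaves the size open). None of the steps to compound 4, whether from compound 1, compound 2 or compound 3, can be read for size, so this change of group has no measured effect that can be stated. On this aromatic carbon, the two compounds with a sulfur-linked chain, compound 1 and compound 4, both end at the same reading, while only the two nitrogen-linked groups of compound 2 and compound 3 give readable numbers: the limit of > 20000 nM in this assay, at which 2 of the 4 values shown sit.

The compounds shown leave open where compound 4 truly lies relative to compound 3. A hexylamino group, which would carry the same six-carbon chain on a nitrogen, could separate the effect of the chain from that of the sulfur.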